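This account rests on a few compounds, and the source may have more. Where it says the series, first, only, none or still open, it means among the compounds named here.

Measured in a physicochemical assay for lipophilicity, using the shake flask method, in phosphate buffer, measured as octanol-water partition, with a stated time of 30 min, at pH 7.4; a higher number here means a more lipophilic compound, a lower number a more polar compound:
- Compound 1 `Cn1cc(-c2cnc(NCc3c(F)ccc4c3CCO4)c3cn[nH]c(=O)c23)cn1`: 2.7
- Compound 2 `O=C1c2ccccc2CN1c1cnc(NCc2c(F)ccc3c2CCO3)n2cnnc12`: 2.7

For the measured compounds named here, compound 1, at 2.7, stands level with compound 2 within the scatter, and the pair offers no measured step to work from. Compound 3 `CN(C)C(=O)c1cc(-c2cnc(NCc3c(F)ccc4c3CCO4)c3cn[nH]c(=O)c23)n(C)n1` keeps the core of compound 1 and changes one group: 3-(dimethylcarbamoyl)-1-methyl-1H-pyrazol-5-yl in place of 1-methyl-1H-pyrazol-4-yl on an aromatic carbon. Going by the values given here, with no measured precedent for this change, only a small fall in this assay is expected, about the size of the scatter. The expected change is a number 0.20 log units lower from compound 1 to compound 3 (within the scatter). The estimate for compound 3 is 2.5, with an expected range from 2.1 to 2.9.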

Compound 3, distribution coefficient: 2.1
Compound 3: the middle estimate sits 0.40 log units above what was measured; measured number inside the range.
By their numbers in this assay, from the lowest: compound 3; then compounds 1 and 2 (each within the scatter of the next).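

For the compounds shown here, on this aromatic carbon of the core of compound 1, 3-(dimethylcarbamoyl)-1-methyl-1H-pyrazol-5-yl in place of 1-methyl-1H-pyrazol-4-yl gives a number 0.60 log units lower from compound 1 to compound 3 (beyond the scatter) in this assay and is the first step read at this position. That single step joins two differences: the added dimethylcarbamoyl group and the changed point of attachment of the pyrazole. No measurement available here bears on the origin of the step.

Which of the two differences carries the step stays open. Also open, on these data alone, is how a plain 1-methyl-1H-pyrazol-5-yl, or a carboxylic acid or an amine in place of the dimethylcarbamoyl group, would read in this assay on this carbon.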